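The compounds below may be only part of what the source reports. "The series", "measured", "known", "first", "only" and "open" are said of these compounds alone.

Measured so far:
- compound 1, `CCCCCCOc1ccc(C(=O)NCCN(CC)CC)cc1`: 3500 nM
- compound 2, `CCCCCCOc1ccc(C(=O)NCC2CCCC2(C)C)cc1`: 710 nM; 160 nM (2 entries)

Compound 1 stands on a single number in an assay for activation of potassium voltage-gated channel subfamily KQT member 1 (Cavia porcellus); a lower number here means a stronger inhibitor, a higher number a weaker inhibitor; one further entry carries no single value. For the measured compounds named here, the only other measured compound, compound 2, is covered by the several entries of compound 2 in this assay, 710 nM; 160 nM (2 entries), and those entries sit at lower numbers than the one value of compound 1.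

The unmeasured compound 3, `CCCCCCOc1ccc(C(=O)NC2CCC(C)(C)C2)cc1`, differs from compound 1 by 3,3-dimethylcyclopentyl in place of 2-(diethylamino)ethyl on an amide-type nitrogen. No measured step of this kind is shown, so the expectation rests on the two measured compounds alone: compound 2, which also carries a dimethyl-substituted five-membered ring on the amide nitrogen, gives lower numbers than compound 1. For compound 3 a step toward stronger inhibition is therefore expected, a 5.8-fold lower number from compound 1 to compound 3 (0.77 log units; beyond the scatter), in this assay. The estimate for compound 3 is 600 nM, with a range from 150 nM to 2500 nM.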

Compound 3, half-maximal inhibitory concentration: 360 nM
Compound 3: middle estimate off by 1.7-fold (0.22 log units), on the high side; the range from low to high includes it.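

On the amide-type nitrogen, 3,3-dimethylcyclopentyl in place of 2-(diethylamino)ethyl gives, in this assay, a 9.7-fold lower number from compound 1 to compound 3 (0.99 log units; beyond the scatter). For the compounds shown here, this is the first readable step at this position, and it shows that a nitrogen in this group is not required for a lower number: the entering ring is carbon only and has no hydrogen-bond acceptor, while the heavy-atom count stays the same. Compound 3, at 360 nM, lies within the span of the other compound with a dimethyl-substituted five-membered ring on this nitrogen: the several entries of compound 2 in this assay, 710 nM; 160 nM (2 entries)

The step changes the ring and the nitrogen together, so the share of each remains unresolved. Also open, going by these compounds, is how an open-chain 3,3-dimethylbutyl group or an unsubstituted cyclopentyl group would read on this nitrogen.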